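Swapping trifluoromethyl for phenyl on two related cores

This account rests on a few compounds, and the source may have more. Where it says the series, first, only, none or still open, it means among the compounds named here.

Compound 1 `O=C(O)CCc1ccc(NCc2cccc(C(F)(F)F)c2)cc1` and compound 2 `O=C(O)CCc1ccc(OCc2cccc(C(F)(F)F)c2)cc1` share most of their structure but differ in the link between the two rings; the difference between the two cores is not broken down here. In a functional assay on 1321-N1 cells for agonist activity at Free fatty acid receptor 1 (Homo sapiens), read by calcium flux (on this read-out higher numbers stand for an effect only at larger amounts of compound and lower numbers for an effect already at smaller amounts), compound 1 gives 186 nM and compound 2 gives 83.2 nM. Compound 3 `O=C(O)CCc1ccc(OCc2cccc(-c3ccccc3)c2)cc1` is built on the core of compound 2 and carries phenyl in place of trifluoromethyl on an aromatic carbon. In this assay compound 3 gives 135 nM, a step of a 1.6-fold higher number from compound 2 to compound 3 (0.21 log units; within the scatter). Compound 4 `O=C(O)CCc1ccc(NCc2cccc(-c3ccccc3)c2)cc1` has not yet been measured; it is built on the core of compound 1 and carries the same change, (phenyl in place of trifluoromethyl on an aromatic carbon), at a place described in the same words, meta to a large group. Because the step of a 1.6-fold higher number from compound 2 to compound 3 (0.21 log units; within the scatter) was small, the same change on the core of compound 1 is expected to move the number only a little as well. In this assay compound 4 is therefore expected to give about 290 nM, with a likely range from 140 nM to 600 nM. This estimate means an expected step of a 1.6-fold higher number from compound 1 to compound 4 (0.19 log units; within the scatter), staying within the usual scatter.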

Compound 4, half-maximal effective concentration: 53.7 nM
Compound 4: the middle estimate sits 5.4-fold (0.73 log units) above what was measured; measured number outside the range, below it.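

In this assay, putting phenyl in place of trifluoromethyl on the core of compound 1 gives a 3.5-fold lower number from compound 1 to compound 4 (0.54 log units; beyond the scatter), a clear shift towards effect at smaller amounts of compound. The result of this change therefore did not carry over unchanged from one core to the other, so a small step on one core gave no safe guide to the step on the other: the same change on two cores in this assay, a 1.6-fold higher number (0.21 log units; within the scatter) from compound 2 to compound 3 and a 3.5-fold lower number (0.54 log units; beyond the scatter) from compound 1 to compound 4, 5.6-fold (0.75 log units) apart, beyond the scatter of two such steps. Among these compounds, this does not show why the two cores respond differently, and with only one pair on each core it gives no rule for how the same change would behave on any further core.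

The compounds shown leave open whether other groups on the same aromatic carbon, such as methyl, chlorine or methoxy, would also respond differently on the two cores. They also leave open whether the gap between the two steps would persist with another link between the rings, such as an amide or a longer chain.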